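A few compounds are considered here, and "the series" means these few. Any claim that something is new, unique, unknown or untested is made for them only; others in the source may bear on it.

Measured so far in an ADME assay on L6 cells (Rattus norvegicus) for cytotoxicity, read by resazurin assay, with a stated time of 72 h; on this read-out higher numbers stand for weaker inhibition and lower numbers for stronger inhibition:
- Compound 1 `OC(c1ccc(Cl)cc1)(c1cccnc1)c1ccccc1Cl`: 61300 nM
- Compound 2 `OC(c1ccc(Cl)cc1)(c1cccnc1)c1cccc(F)c1`: 66000 nM
- Compound 3 `OC(c1ccc(Cl)cc1)(c1cnccn1)c1ccccc1Cl`: > 100000 nM (a limit of the assay, not a number)

Compound 1 stands at the low end of these values, but its nearest neighbour shows no real difference: a 1.1-fold higher number from compound 1 to compound 2 (0.03 log units; within the scatter). The other measured step is also small, and it rests on a limit: an at least 1.6-fold higher number from compound 1 to compound 3 (0.21 log units; that floor lies within the scatter).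

Compound 4 `CC(C)CNC(c1ccc(Cl)cc1)(c1cccnc1)c1ccccc1Cl` carries isobutylamino in place of hydroxy on a saturated chain carbon bound to three aromatic carbons. Neither measured step touches the hydroxy, since both exchanged an aromatic group, so they offer only indirect guidance. Starting from compound 1 at 61300 nM, the larger incoming group makes a modest shift towards stronger inhibition in this assay a cautious expectation, though not a certain one. The expected change is a 3.1-fold lower number from compound 1 to compound 4 (0.49 log units; beyond the scatter). For compound 4 the estimated value is 20000 nM, with an expected range from 6000 nM to 60000 nM.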

Compound 4, half-maximal inhibitory concentration: 59200 nM
Beside the measured number, compound 4's estimate is 3.0-fold (0.47 log units) below it; the range from low to high includes it.
By their numbers in this assay, from the lowest: compounds 4, 1 and 2 (each within the scatter of the next). At a limit, above all of these: compound 3.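

In this assay the first change made at the hydroxy itself, on a saturated chain carbon bound to three aromatic carbons, gives no real shift in the read-out (a 1.0-fold lower number from compound 1 to compound 4 (0.02 log units; within the scatter)). The earlier steps shown here exchanged only aromatic groups, so they could not show that isobutylamino, with 5 heavy atoms, can stand in place of hydroxy, with 1 heavy atom, and leave the number within the scatter. Nothing on hand explains why this exchange makes so little difference.

Going by these compounds, whether the same holds for a plain amino group, a methoxy group or a longer chain remains open. On these data alone, it is also open whether isobutylamino would behave the same way on a compound carrying pyrazin-2-yl or 3-fluorophenyl instead of the aromatic groups of compound 1.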